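Replacing chloro with methyl in compound 3

The source may report more compounds than this note shows. Statements on the series, on what has been measured and on what is new or still open speak of the compounds shown alone.

Values so far in a functional assay on HepG2 cells (Homo sapiens) for inhibition, read by MTT assay, with a stated time of 48 h; on this read-out higher numbers stand for weaker inhibition and lower numbers for stronger inhibition
compound 1 `O=C(C=CNc1cc(-c2ccccc2)nn1-c1ccccc1)c1cccs1` gives 2420 nM
compound 2 `O=C(C=CNc1cc(-c2ccccc2)nn1-c1ccccc1)c1ccccc1` gives 2660 nM
compound 3 `O=C(C=CNc1cc(-c2ccccc2)nn1-c1ccccc1)c1ccc(Cl)cc1` gives 41200 nM

Compound 3 stands at the weak end of this small set, with the highest number of the three. Compound 4 `Cc1ccc(C(=O)C=CNc2cc(-c3ccccc3)nn2-c2ccccc2)cc1` keeps the shared core and has not yet been measured. It carries methyl in place of chloro on an aromatic carbon, para to a large group methyl in place of chloro on an aromatic carbon and nothing else changes.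

Within the data shown here, three measured steps bear on this. The closest is a 15-fold higher number from compound 2 to compound 3 (1.19 log units; beyond the scatter) on adding chloro in place of hydrogen, and a 17-fold higher number from compound 1 to compound 3 (1.23 log units; beyond the scatter) is of similar size. By contrast, a 1.1-fold higher number from compound 1 to compound 2 (0.04 log units; within the scatter) shows no separation between the two compounds without chloro. Among the measured compounds shown here, compound 3 is the only compound here with chloro, but no measured step replaces chloro with methyl, so the outcome remains open. A large step toward a lower number is expected, recovering part of that gap.

The expected change is a 4.6-fold lower number from compound 3 to compound 4 (0.66 log units; beyond the scatter) in this assay and is only an estimate. For compound 4 the estimated value is 9000 nM, with an expected range of 2500 nM to 40000 nM.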

Compound 4, half-maximal inhibitory concentration: 7320 nM
Beside the measured number, compound 4's estimate is 1.2-fold (0.09 log units) above it; low and high end bracket the measured number.
By their numbers in this assay, from the lowest: compounds 1 and 2 (each within the scatter of the next); then compound 4; then compound 3.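

In this assay, the heavy penalty seen with chloro on this aromatic carbon, para to a large group, does not extend in full to every group placed there: a 5.6-fold lower number from compound 3 to compound 4 (0.75 log units; beyond the scatter) when methyl takes the place of chloro. Methyl does not match hydrogen either, as a 2.8-fold higher number from compound 2 to compound 4 (0.44 log units; beyond the scatter) when methyl takes the place of hydrogen and a 3.0-fold higher number from compound 1 to compound 4 (0.48 log units; beyond the scatter) when 4-methylphenyl takes the place of thiophen-2-yl, so a single carbon at this position already shifts the read-out by a modest step, though by far less than chloro does. Nothing measured here accounts for the difference between chloro and methyl at this position.

With only hydrogen, methyl and chloro shown at this position, it remains open how a methoxy group, an amine or a carboxylic acid would read there. On these data alone, it is also open whether a longer chain would move the number further, or whether methyl on the thiophen-2-yl ring of compound 1 would give a step of similar size.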